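Sulfonylmethyl Heterocycle Swap Across Two Cores in One Assay

A few compounds are considered here, and "the series" means these few. Any claim that something is new, unique, unknown or untested is made for them only; others in the source may bear on it.

Measured so far:
compound 1, `COc1ccc(C2=NN(c3ccccc3)C(c3ccc(C)cc3)C2S(=O)(=O)CC2=NCCO2)cc1`, 64.3% in a functional assay, tested at 75 ug/mL; a higher number here means a stronger effect of the compound at the concentration tested, a lower number a weaker effect
compound 2, `COc1ccc(C2=NN(c3ccccc3)C(c3ccc(C)cc3)C2S(=O)(=O)CC2=NCCS2)cc1`, 43.9% in this assay
compound 3, `COc1ccc(-c2noc(-c3ccc(C)cc3)c2S(=O)(=O)CC2=NCCS2)cc1`, reported as "not active" (no number reported) in this assay

Within the core of compound 1 and compound 2, the change a group of 5 heavy atoms (3 carbon, 1 nitrogen, 1 oxygen; one five-membered non-aromatic ring with 2 hetero atoms) in place of a group of 5 heavy atoms (3 carbon, 1 nitrogen, 1 sulfur; one five-membered non-aromatic ring with 2 hetero atoms), on a saturated chain carbon bound to a sulfonyl sulfur gives a number 20.4 percentage points higher from compound 2 to compound 1 (beyond the scatter). Compound 4, `COc1ccc(-c2noc(-c3ccc(C)cc3)c2S(=O)(=O)CC2=NCCO2)cc1`, carries the same kind of change on the core of compound 3: a group of 5 heavy atoms (3 carbon, 1 nitrogen, 1 oxygen; one five-membered non-aromatic ring with 2 hetero atoms) in place of a group of 5 heavy atoms (3 carbon, 1 nitrogen, 1 sulfur; one five-membered non-aromatic ring with 2 hetero atoms), on a saturated chain carbon bound to a sulfonyl sulfur. Among the measured compounds shown here, the difference between the two cores is not broken down here; compound 3 gives no number in this assay, so no step from compound 3 to compound 4 can be counted, and the only guide is the step seen between compound 2 and compound 1. Since compound 3 itself is reported as not active, a step of similar size would still leave compound 4 near the weak end. Compound 4 is therefore expected to give about 15% in this assay, with 0% to 40% as the plausible range, and a real chance that it is again reported only as not active.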

Compound 4, a percentage reported as activity, at one concentration (the size of the read-out at that concentration, not a potency): 72%
Compound 4: middle estimate off by 57 percentage points, on the low side, and the stated range ends below it.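

Among the compounds shown here, compound 3 carries no number in this assay, and no step from it to compound 4 can be read. The compounds shown leave open how large the heterocycle swap is on this core. No measurement at hand explains the result.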